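Changing the sulfonamide ring of compound 1

The compounds below may be only part of what the source reports. "The series", "measured", "known", "first", "only" and "open" are said of these compounds alone.

Measured so far in a physicochemical assay for lipophilicity (on this read-out lower numbers stand for lower lipophilicity and higher numbers for higher lipophilicity), are three compounds:
compound 1 `Cn1nccc1-c1cc(C(F)(F)F)ccc1[C@H]1CCOc2cc(S(=O)(=O)Nc3nccs3)ccc21` gives 2.2
compound 2 `O=S(=O)(Nc1nccs1)c1ccc2c(c1)OCC[C@@H]2c1ccc(C(F)(F)F)cc1-c1ccc(F)cc1` gives 4.5
compound 3 `Cc1nc(-c2cc(C(F)(F)F)ccc2[C@H]2CCOc3cc(S(=O)(=O)Nc4nccs4)ccc32)co1` gives 2.9

Of these three, compound 1 stands lowest, with compound 3 nearest and compound 2 furthest. The next compound, compound 4 `Cn1nccc1-c1cc(C(F)(F)F)ccc1[C@H]1CCOc2cc(S(=O)(=O)Nc3ccncn3)ccc21`, keeps the core of compound 1 and changes a single group: pyrimidin-4-yl in place of 1,3-thiazol-2-yl on a sulfonamide nitrogen. The three measured steps all concern a different group, on an aromatic carbon. They are a number 2.30 log units higher from compound 1 to compound 2 (beyond the scatter), a number 0.70 log units higher from compound 1 to compound 3 (beyond the scatter) and a number 1.60 log units lower from compound 2 to compound 3 (beyond the scatter). Among the measured compounds shown here, these steps show how far the read-out moved when that group changed, but none of them touches the sulfonamide nitrogen, so the data hold no direct precedent for this change. Their size is therefore not carried over, and the estimate starts from compound 1 (2.2). In this assay the expected change is small and downward, a number 0.20 log units lower from compound 1 to compound 4 (within the scatter), and it may not clear the scatter. For compound 4 the estimated value is 2, with an expected range from 1.4 to 2.6.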

Compound 4, distribution coefficient: 1.8
Beside the measured number, compound 4's estimate is 0.20 log units above it; low and high end bracket the measured number.
By their numbers in this assay, from the lowest: compound 4; then compound 1; then compound 3; then compound 2.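

In this assay, among the compounds shown here, the sulfonamide nitrogen proves to be a position where the read-out moves, with pyrimidin-4-yl in place of 1,3-thiazol-2-yl giving a number 0.40 log units lower from compound 1 to compound 4 (beyond the scatter) and thereby supplying the first step at this position rather than on an aromatic carbon. The step is modest and beyond the scatter, and it places compound 4 lowest of the four compounds. The two groups have the same counts of hydrogen-bond donors and acceptors, so those counts do not distinguish them, and no measurement shown accounts for the step.

The compounds shown leave open whether the same change would give a similar step with 4-fluorophenyl or 2-methyl-1,3-oxazol-4-yl on the aromatic carbon, as pyrimidin-4-yl appears here only with 1-methyl-1H-pyrazol-5-yl. They also leave open how other groups on a sulfonamide nitrogen, such as pyridin-2-yl or 1,2,4-thiadiazol-5-yl, would read in this assay relative to 1,3-thiazol-2-yl and pyrimidin-4-yl.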